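From Pyridin-3-yl to 4-Chlorophenyl on a Shared Core

The source may hold more compounds than are shown below. What is called first, only, known or untested is meant among the compounds shown, and "the series" means these compounds.

Of the compounds shown here, three built on one shared core have been tested in an assay on isolated protein for inhibition of DNA topoisomerase 1 (Homo sapiens), tested at 100 uM; a lower number here means a weaker effect, a higher number a stronger effect of the compound at the concentration tested. Compound 2 `Clc1ccc(-c2cc(-c3cccnc3)nc(-c3cccs3)c2)o1` gives 25.8%. Compound 1 `Cc1cccc(-c2cc(-c3ccc(Cl)o3)cc(-c3ccsc3)n2)c1` gives 7.5%, and compound 3 `Clc1ccc(-c2cc(-c3cccnc3)nc(-c3ccsc3)c2)o1` gives 0%. Among these three numbers compound 2 stands highest, with compound 1 the nearest and compound 3 the furthest, both beyond the scatter.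

Compound 4 `Clc1ccc(-c2cc(-c3ccc(Cl)o3)cc(-c3cccs3)n2)cc1` has not yet been measured. It differs from compound 2 in one place: 4-chlorophenyl in place of pyridin-3-yl on an aromatic carbon.

Within the data shown here, one measured step bears on this exchange. The step of a number 7.5 percentage points lower from compound 1 to compound 3 (within the scatter) swaps a carbon-only ring against pyridin-3-yl at the same place and stays within the scatter, so the reverse kind of swap in compound 4 is expected to move the number little. The step of a number 25.8 percentage points lower from compound 2 to compound 3 (beyond the scatter) touches a different group and is not directly comparable. Compound 4 is therefore estimated at 25%, within a range from 8% to 45%, which means an expected step of a number 0.8 percentage points lower from compound 2 to compound 4 (within the scatter).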

Compound 4, a percentage reported as inhibition, at one concentration (the size of the read-out at that concentration, not a potency): 38.9%
Compound 4: the middle estimate sits 13.9 percentage points below what was measured; low and high end bracket the measured number.
By their numbers in this assay, from the lowest: compounds 3 and 1 (each within the scatter of the next); then compound 2; then compound 4.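

This position responds to the ring placed on it: in this assay there is a number 13.1 percentage points higher from compound 2 to compound 4 (beyond the scatter) when 4-chlorophenyl replaces pyridin-3-yl. The earlier exchange of 3-methylphenyl for pyridin-3-yl, a number 7.5 percentage points lower from compound 1 to compound 3 (within the scatter), could not show this, since it stayed within the scatter and carried thiophen-3-yl rather than thiophen-2-yl. The result also shows that, with thiophen-2-yl present, the ring nitrogen and its hydrogen-bond acceptor are not needed for a reading at this level, although nothing here explains the rise.

Still open, as far as these compounds go, is whether the chlorine or the carbon-only ring accounts for the step, which plain phenyl would separate. From the compounds shown here alone, it is also open how this position would respond to a group of another kind, such as a carboxylic acid or an amine on a longer chain.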